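Three Analogues Beyond the Limit, and One Still Untested

The compounds below may be only part of what the source reports. "The series", "measured", "known", "first", "only" and "open" are said of these compounds alone.

compound 1, `CN(CC(=O)N1CCN(c2ccc(C(F)(F)F)cc2)CC1)C(=O)c1ccc(S(C)(=O)=O)c([N+](=O)[O-])c1`, in an assay on isolated protein for inhibition of vitamin D3 receptor (Homo sapiens), read by fluorescence polarization (on this read-out higher numbers stand for weaker inhibition and lower numbers for stronger inhibition), gives > 60000 nM, a limit of the assay.
compound 2, `CC(C)N(C(=O)C1CCN(C(=O)c2ccc(S(C)(=O)=O)c([N+](=O)[O-])c2)CC1)C(C)C`, in this assay gives > 60000 nM, a limit of the assay.
compound 3, `CN(Cc1ccccc1F)C(=O)CNC(=O)c1ccc(S(C)(=O)=O)c([N+](=O)[O-])c1`, in this assay gives > 60000 nM, a limit of the assay.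

Compound 2 therefore stands where the other two stand: the limit of > 60000 nM in this assay, at which 3 of the 3 values shown sit. Within the data shown here, no step between measured compounds can be computed, so nothing shows how a change at the amide end of the shared core moves the read-out. Compound 4, `CC1Cc2ccccc2N1C(=O)C1CCN(C(=O)c2ccc(S(C)(=O)=O)c([N+](=O)[O-])c2)CC1`, is not yet measured; it differs from compound 2 thus: 2-methyl-2,3-dihydro-1H-indol-1-yl in place of diisopropylamino on a carbonyl carbon. In this assay the step is expected to be none beyond the scatter, so a step that the limit leaves unreadable from compound 2 to compound 4 is the estimate. Compound 4 is expected to give 80000 nM, between 20000 nM and 300000 nM.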

Compound 4, half-maximal inhibitory concentration: > 60000 nM
Compound 4: a limit, no number; the forecaster's own chance of this, stated with the estimate: 85%; the middle value is on the limit's open side.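

Compound 4 sits at the same limit as compound 2, so no step between them can be read: the limit of > 60000 nM in this assay, at which 4 of the 4 values shown sit.

What change to the shared core, if any, would give a readable number in this assay is left open by the compounds shown.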